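The source may hold more compounds than are shown below. What is called first, only, known or untested is meant among the compounds shown, and "the series" means these compounds.

Measured compounds in an ADME assay on NIH3T3 cells (Mus musculus) for cytotoxicity, read by MTT assay, with a stated time of 24 h; on this read-out lower numbers stand for stronger inhibition and higher numbers for weaker inhibition:
Compound 1 `COc1ccc(-c2cs/c(=N/NC(=O)CSc3nnnn3-c3ccccc3)n2-c2ccccc2)cc1`: 11.7 ug/mL
Compound 2 `COc1ccc(-c2cs/c(=N/NC(=O)CSc3nnnn3C)n2-c2ccccc2)cc1`: 45 ug/mL
Compound 3 `O=C(CSc1ncccn1)N/N=c1/scc(-c2ccccc2)n1-c1ccccc1`: 107 ug/mL

Compound 1 gives the lowest of the three numbers; its nearest neighbour is compound 2, which stands higher by a 3.8-fold higher number from compound 1 to compound 2 (0.59 log units; beyond the scatter), a step brought about by methyl in place of phenyl on an aromatic nitrogen. Compound 3 stands further away still, but it differs from compound 1 in more than one place, so its two values show only a wide gap.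

The step to be judged leads from compound 1 to compound 4 `O=C(CSc1nnnn1-c1ccccc1)N/N=c1/scc(-c2ccc([N+](=O)[O-])cc2)n1-c1ccccc1`. The change is nitro in place of methoxy on an aromatic carbon, in words: nitro in place of methoxy on an aromatic carbon, or 4-methoxyphenyl to 4-nitrophenyl. For the measured compounds named here, no measured step touches this part of the shared core; the one single-point step concerns the aromatic nitrogen. There is therefore no basis for expecting a step beyond the scatter in this assay in either direction. Compound 4 is estimated at 14 ug/mL, within 5 ug/mL to 40 ug/mL, which means an expected step of a 1.2-fold higher number from compound 1 to compound 4 (0.08 log units; within the scatter).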

Compound 4, half-maximal inhibitory concentration: 14.3 ug/mL
For compound 4 the middle estimate is 1.0-fold (0.01 log units) below the measured one; the measured number falls inside the stated range.
By their numbers in this assay, from the lowest: compounds 1 and 4 (each within the scatter of the next); then compound 2; then compound 3.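

For the compounds shown here, the swap of 4-methoxyphenyl to 4-nitrophenyl gives the first single-point reading at this position in this assay, with a 1.2-fold higher number from compound 1 to compound 4 (0.09 log units; within the scatter) as its result. On this aromatic carbon, para to a large group, methoxy and nitro therefore cannot be told apart on this read-out, whereas the step on the aromatic nitrogen, a 3.8-fold higher number from compound 1 to compound 2 (0.59 log units; beyond the scatter), lies beyond the scatter. Nothing measured here offers an explanation for the close agreement of the two values.

Going by these compounds, with only these two groups compared at this place, it remains open whether an amine or a carboxylic acid there would stay within the scatter of compound 1. On these data alone, it is also open whether the nitro group would give the same reading alongside the methyl on the aromatic nitrogen seen in compound 2.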